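Swapping chloro for amino on the pyridine of compound 2

The source may hold more compounds than are shown below. What is called first, only, known or untested is meant among the compounds shown, and "the series" means these compounds.

Measured so far in an assay on isolated protein for inhibition of Nicotinamide phosphoribosyltransferase (Homo sapiens), read by fluorescence, with stated times of 5 min and 15 min; a lower number here means a stronger inhibitor, a higher number a weaker inhibitor: compound 1 `Nc1ccccc1NC(=O)c1ccc(NC(=O)NCc2cccnc2)cc1` gives 550 nM. Compound 2 `Nc1ccccc1NC(=O)c1ccc(NC(=O)NCc2ccc(Cl)nc2)cc1` reaches only a limit of this assay, > 2000 nM. Compound 3 `Cc1ccc(CNC(=S)Nc2ccc(C(=O)Nc3ccccc3N)cc2)cn1` likewise sits at a limit, > 2000 nM.

Compound 2 therefore stands at the limit of > 2000 nM in this assay, at which 2 of the 3 values shown sit, rather than at a number. Among the compounds with values here, the one measured step that touches it is an at least 3.6-fold higher number from compound 1 to compound 2 (0.56 log units; beyond the scatter), chloro in place of hydrogen on an aromatic carbon. Compound 4 `Nc1ccc(CNC(=O)Nc2ccc(C(=O)Nc3ccccc3N)cc2)cn1` changes the same carbon again: amino in place of chloro on an aromatic carbon, next to the ring nitrogen, para to a large group. Within the data shown here, no measured step shows amino at this position, so the direction is open; the only anchor is that compound 1 with hydrogen there gave a number. Compound 4 is therefore estimated at 1500 nM, between 400 nM and 5000 nM, which would mean an expected step of an at least 1.3-fold lower number from compound 2 to compound 4 (0.12 log units; that floor lies within the scatter).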

Compound 4, half-maximal inhibitory concentration: > 2000 nM
Compound 4: a limit, no number; the forecaster's own chance of this, stated with the estimate: 40%; middle value at least 1.3-fold (0.12 log units) away from the limit.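

In this assay compound 4 also sits at a limit, > 2000 nM. Set against hydrogen on this carbon, amino gives an at least 3.6-fold higher number from compound 1 to compound 4 (0.56 log units; beyond the scatter), so chloro and amino, which differ in their atoms and hydrogen-bond counts, both move the number the same way, and only hydrogen here still gives a measured number. The step between chloro and amino cannot be read, because both values are limits: the limit of > 2000 nM in this assay, at which 3 of the 4 values shown sit.

As far as these compounds go, whether any replacement for hydrogen on this carbon keeps a measured number stays open. Fluoro or methoxy here would test that.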